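This account rests on a few compounds, and the source may have more. Where it says the series, first, only, none or still open, it means among the compounds named here.

Compound 1 `C(#Cc1nc2c(s1)CN(C1CCCCC1)CC2)c1ccccc1` in an assay on HEK293 cells for negative allosteric modulation of metabotropic glutamate receptor 5 (Homo sapiens), read by FLIPR, with a stated time of 1 h (on this read-out lower numbers stand for stronger inhibition and higher numbers for weaker inhibition), gives > 10000 nM, a limit of the assay.
Compound 2 `CC(=O)N1CCc2nc(C#Cc3ccccc3)sc2C1` in this assay gives 90 nM.
Compound 3 `O=C(C1CC(F)C1)N1CCc2nc(C#Cc3ccccc3)sc2C1` in this assay gives > 10000 nM, again a limit.

Compound 3 thus stands at the limit of > 10000 nM in this assay, at which 2 of the 3 values shown sit, and has no number of its own. Compound 4 `O=C(C1CCCC1)N1CCc2nc(C#Cc3ccccc3)sc2C1` differs from it by cyclopentyl in place of 3-fluorocyclobutyl on a carbonyl carbon. Going by the values given here, no measured step repeats this change. The step that bears on it is an at least 110-fold higher number from compound 2 to compound 3 (2.04 log units; beyond the scatter), in which a ring acyl group replaced acetyl on the amide; the step that the two limits leave unreadable from compound 1 to compound 3 yields no size. Cyclopentyl is again a ring acyl group rather than methyl. Compound 4 is expected to stay near the limit, the expected step being an at least 1.2-fold lower number from compound 3 to compound 4 (0.09 log units; that floor lies within the scatter), given the size of an at least 110-fold higher number from compound 2 to compound 3 (2.04 log units; beyond the scatter). Compound 4 is estimated at 8000 nM, range 1500 nM to 30000 nM.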

Compound 4, half-maximal inhibitory concentration: > 10000 nM
Compound 4 was reported as a limit; the forecaster's own chance of this, stated with the estimate: 65%; middle value at least 1.2-fold (0.09 log units) from the limit.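

Cyclopentyl on the carbonyl carbon repeats in this assay what 3-fluorocyclobutyl showed: replacing methyl there gives an at least 110-fold higher number from compound 2 to compound 4 (2.04 log units; beyond the scatter), so the loss does not depend on the fluorine or on the four-membered ring. The steps from compound 3 and from compound 1 to compound 4 cannot be read: both ends of each are limits. The series now sits largely at one limit: the limit of > 10000 nM in this assay, at which 3 of the 4 values shown sit.

What remains open is how ethyl or cyclopropyl on the carbonyl carbon would read, as both stand apart from methyl and from the two rings shown. Going by these compounds alone, compound 2 remains the only compound here with a number of its own.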